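Replacing the Benzamido Group of Compound 3

The source may hold more compounds than are shown below. What is called first, only, known or untested is meant among the compounds shown, and "the series" means these compounds.

For the measured compounds named here, in a physicochemical assay for solubility, read by LC-MS, in phosphate buffer, with a stated time of 24 h, at pH 7.4 (a lower number here means a less soluble compound, a higher number a more soluble compound), compound 3 (`O=C(Nc1cnc(NCc2c(F)ccc3c2CCO3)n2cnnc12)c1ccccc1`) gives 2000 nM, the lowest of three numbers so far. Compound 1 (`COCCC(=O)Nc1cnc(NCc2c(F)ccc3c2CCO3)n2cnnc12`) gives 980000 nM and compound 2 (`CN(C(=O)c1ccccc1)c1cnc(NCc2c(F)ccc3c2CCO3)n2cnnc12`) gives 280000 nM in the same test. Unmeasured compound 4 (`CN(c1cccnc1)c1cnc(NCc2c(F)ccc3c2CCO3)n2cnnc12`) has methyl(pyridin-3-yl)amino in place of benzamido on an aromatic carbon. The closest guide is a large step, a 140-fold lower number from compound 2 to compound 3 (2.15 log units; beyond the scatter), with hydrogen in place of methyl on an amide-type nitrogen. Another large step, a 490-fold lower number from compound 1 to compound 3 (2.69 log units; beyond the scatter), shows how far this series can move. Going by the values given here, compound 4 has that methyl but no carbonyl, so no measured step matches it exactly. A large rise is therefore expected, with the estimated change being a 50-fold higher number from compound 3 to compound 4 (1.70 log units; beyond the scatter). The estimate for compound 4 is 100000 nM, with an expected range from 20000 nM to 500000 nM.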

Compound 4, solubility: 47000 nM
The estimate for compound 4 lay 2.1-fold (0.33 log units) above the measured number; low and high end bracket the measured number.
By their numbers in this assay, from the lowest: compound 3; then compound 4; then compound 2; then compound 1.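

In this assay, a group with no carbonyl and no amide hydrogen can stand on this aromatic carbon and still give a 24-fold higher number from compound 3 to compound 4 (1.37 log units; beyond the scatter) instead of the low benzamido reading. Pyridin-3-yl does not fully match benzoyl on the methylated nitrogen, giving a 6.0-fold lower number from compound 2 to compound 4 (0.78 log units; beyond the scatter) and, against the methoxyethyl amide, a 21-fold lower number from compound 1 to compound 4 (1.32 log units; beyond the scatter) in the same test. Nothing measured here explains these shifts. Still open, from the compounds shown here alone, is how methyl(phenyl)amino would read, which would show what the ring nitrogen of pyridin-3-yl contributes on its own. A morpholine or a simple amine on this carbon also remains an open comparison.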